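The compounds below may be only part of what the source reports. "The series", "measured", "known", "first", "only" and "open" are said of these compounds alone.

Measured compounds in a functional assay on Bel7402/5-FU cells (Homo sapiens) for antiproliferative activity, read by MTT assay, with a stated time of 72 h; on this read-out higher numbers stand for weaker inhibition and lower numbers for stronger inhibition:
Compound 1 `C=C1C(=O)O[C@H]2[C@H]1CC/C(COC(=O)Cn1cc(F)c(=O)[nH]c1=O)=C\CC[C@@]1(C)O[C@@H]21` gives > 20000 nM, which is a limit of the assay rather than a number.
Compound 2 `C=C1C(=O)O[C@H]2[C@H]1CC/C(COC(=O)Cn1cc(F)c(=O)n(Cc3ccc(F)cc3)c1=O)=C\CC[C@@]1(C)O[C@@H]21` gives 1140 nM.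
Compound 3 `C=C1C(=O)O[C@H]2[C@H]1CC/C(COC(=O)Cn1cc(F)c(=O)n(Cc3cccc(F)c3)c1=O)=C\CC[C@@]1(C)O[C@@H]21` gives 3700 nM.

Compound 1 thus stands at the limit (the limit of > 20000 nM in this assay, at which 1 of the 3 values shown sits), and only a range is known for it. Compound 4 `C=C1C(=O)O[C@H]2[C@H]1CC/C(COC(=O)Cn1cc(F)c(=O)n(Cc3cc(F)ccc3F)c1=O)=C\CC[C@@]1(C)O[C@@H]21` differs from compound 1 by 2,5-difluorobenzyl in place of hydrogen on an aromatic nitrogen. Among the compounds with values here, the steps that bear on this change are an at least 17-fold lower number from compound 1 to compound 2 (1.24 log units; beyond the scatter) and an at least 5.4-fold lower number from compound 1 to compound 3 (0.73 log units; beyond the scatter), each of which also placed a fluorobenzyl group on the same aromatic nitrogen; between those two products there is a 3.2-fold higher number from compound 2 to compound 3 (0.51 log units; beyond the scatter). A drop in the number beyond the scatter is therefore expected for compound 4, namely an at least 8.0-fold lower number from compound 1 to compound 4 (0.90 log units; beyond the scatter). Compound 4 is estimated at 2500 nM, within the range 800 nM to 8000 nM.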

Compound 4, half-maximal inhibitory concentration: 4610 nM
The estimate for compound 4 lay 1.8-fold (0.27 log units) below the measured number; low and high end bracket the measured number.
By their numbers in this assay, from the lowest: compound 2; then compounds 3 and 4 (each within the scatter of the next). At a limit, above all of these: compound 1.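

On the aromatic nitrogen, 2,5-difluorobenzyl also improves on hydrogen in this assay, with an at least 4.3-fold lower number from compound 1 to compound 4 (0.63 log units; beyond the scatter). Compound 1 stands at a limit of the assay, so that step gives only a minimum: the limit of > 20000 nM in this assay, at which 1 of the 4 values shown sits A second fluoro on the ring brings no gain, with a 1.2-fold higher number from compound 3 to compound 4 (0.10 log units; within the scatter), and the 2,5-difluorobenzyl group falls behind 4-fluorobenzyl, with a 4.0-fold higher number from compound 2 to compound 4 (0.61 log units; beyond the scatter).

The compounds shown leave open how an unsubstituted benzyl group would compare. They also leave open what a chloro or methoxy group on the ring, or a longer chain such as phenethyl, would do.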